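Changing the Aniline on the Urea with the Lowest Number of Three

The source may hold more compounds than are shown below. What is called first, only, known or untested is meant among the compounds shown, and "the series" means these compounds.

Three ureas built on a shared core have been measured in a functional assay on PC-9 cells (Homo sapiens) for inhibition, read by MTT assay, with a stated time of 48 h, tested at 10 uM; on this read-out lower numbers stand for less inhibition and higher numbers for more inhibition at the one concentration tested (going by the name of the read-out). Compound 1 `COc1ccc(F)cc1Nc1cc(NC(=O)Nc2c(Cl)cccc2Cl)ncn1` gives 85.5% in this assay. Going by the values given here, compound 3 `COc1ccc(Nc2cc(NC(=O)Nc3c(Cl)cccc3Cl)ncn2)cc1C` gives 80.1% in this assay, and the single measured one-place step, a number 5.4 percentage points lower from compound 1 to compound 3 (within the scatter), stays within the scatter. Among the compounds with values here, compound 2 `COc1cc(NC(=O)Nc2cc(Nc3cccc(C(C)(C)C)c3)ncn2)cc(OC)c1` gives 68% in this assay and stands lowest of the three, beyond the scatter below both compound 3 and compound 1, although no one-place step connects it to either.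

Compound 4 `COc1cc(NC(=O)Nc2cc(Nc3cc(I)ccc3OC)ncn2)cc(OC)c1` has not yet been measured. It differs from compound 2 in one place: 5-iodo-2-methoxyphenyl in place of 3-(tert-butyl)phenyl on a nitrogen on an aromatic ring. Within the data shown here, no measured step exchanges these two groups. Among the measured compounds shown here, the only step that bears on it at all, a number 5.4 percentage points lower from compound 1 to compound 3 (within the scatter), swaps the aryl on the same kind of nitrogen and stays within the scatter, but with a different urea partner. One therefore expects no step beyond the scatter in this assay, with a slight lean upward because compound 1, carrying 5-fluoro-2-methoxyphenyl, gives 85.5%. The expected step is a number 4 percentage points higher from compound 2 to compound 4 (within the scatter). Compound 4 is estimated at 72%, between 56% and 88%.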

Compound 4, a percentage reported as inhibition, at one concentration (the size of the read-out at that concentration, not a potency): 91%
Estimate against measurement, compound 4: 19 percentage points below, and the stated range ends below it.
By their numbers in this assay, from the lowest: compound 2; then compounds 3, 1 and 4 (each within the scatter of the next, the first and the last beyond it).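

With the urea partner of compound 2 held fixed, the aryl group on a nitrogen on an aromatic ring proves able to shift the read-out in this assay: putting 5-iodo-2-methoxyphenyl in place of 3-(tert-butyl)phenyl gives a number 23 percentage points higher from compound 2 to compound 4 (beyond the scatter) at this place. The earlier exchange on this kind of nitrogen, a number 5.4 percentage points lower from compound 1 to compound 3 (within the scatter) with a different urea partner and different aryl groups, had shown no change beyond the scatter. Nothing measured here accounts for the size of the new step.

Going by these compounds, it remains open whether the iodine or the methoxy group goes with the step, and whether the exchange would carry over to the urea of compound 1. Also open, on these data alone, is how an amine or a carboxylic acid in place of the iodine would read in this assay.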